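This account rests on a few compounds, and the source may have more. Where it says the series, first, only, none or still open, it means among the compounds named here.

Measured so far:
Compound 1, `NC(=O)c1ccccc1NC(=O)COc1ccc(Cl)cc1Cl`: < 10%
Compound 2, `Cc1ccc(OCC(=O)Nc2ccc(Cl)cc2C(N)=O)cc1`: 24.1%

Both compounds were tested in a functional assay on K562 cells (Homo sapiens) for inhibition, read by trypan blue exclusion, with a stated time of 24 h, tested at 10 uM; on this read-out higher numbers stand for more inhibition of growth at the one concentration tested and lower numbers for less inhibition of growth. In this assay, compound 1 gives < 10%, which is a limit of the assay and not a number. Its true position can therefore not be pinned down, and any comparison with it stays loose. Compound 2 gives 24.1% in this assay, a reading that is an actual number.

The compound to follow next is compound 3, `NC(=O)c1cc(Cl)ccc1NC(=O)COc1ccc(Cl)cc1Cl`. It keeps the core of compound 1 and makes one change: chloro in place of hydrogen on an aromatic carbon, meta to a carbamoyl group and para to a large group, (chloro in place of hydrogen on an aromatic carbon).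

For the measured compounds named here, no measured pair shows what a single change of this kind does, so the expectation rests on little. Going by the values given here, the only guide is compound 2 at 24.1%, which shows that a close relative can give an actual number. The expected a number at least 8 percentage points higher from compound 1 to compound 3 (that floor lies within the scatter) is a modest rise in growth inhibition, and it may not exceed the usual scatter. For compound 3 the estimated value is 18%, with an expected range of 5% to 40%.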

Compound 3, percent growth inhibition at one concentration: 18.8%
The estimate for compound 3 lay 0.8 percentage points below the measured number, within the range that was stated.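

In this assay, chloro in place of hydrogen on an aromatic carbon, meta to a carbamoyl group and para to a large group, gives a number at least 8.8 percentage points higher from compound 1 to compound 3 (that floor lies within the scatter). Compound 1 gives < 10%, which is a limit of the assay and not a number. For the compounds shown here, this is the first pair here that differs in one place, and it shows that this position can carry a chloro while the reading stays an actual number, but the true size of the step stays unknown because one end of it is a limit: the limit of < 10% in this assay, at which 1 of the 3 values shown sits.

Chloro is the only group other than hydrogen seen at this position, so the compounds shown do not tell whether a bromo group, a methoxy group or an amine there would give a similar reading. They also leave open whether the same exchange of hydrogen for chloro would give a step of similar size in a compound that differs from compound 1 elsewhere in the structure.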